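Selenium for oxygen on the benzyl ring: compound 3

This account rests on a few compounds, and the source may have more. Where it says the series, first, only, none or still open, it means among the compounds named here.

Among the compounds with values here, compound 1 `COc1ccc(CNc2nc(SC)nc3ccccc23)cc1` is one of two compounds measured in a functional assay on HT-29 cells (Homo sapiens) for cytotoxicity, read by MTT assay, with a stated time of 72 h (on this read-out lower numbers stand for stronger inhibition of growth and higher numbers for weaker inhibition of growth), and gives 70200 nM; compound 2 `COc1ccc(CNc2nc([Se]C)nc3ccccc23)cc1` gives 73600 nM, and a 1.0-fold higher number from compound 1 to compound 2 (0.02 log units; within the scatter). Compound 3 `CSc1nc(NCc2ccc([Se]C)cc2)c2ccccc2n1` carries a different change: a group of 2 heavy atoms (1 carbon, 1 selenium; no ring) in place of a group of 2 heavy atoms (1 carbon, 1 oxygen; no ring), on an aromatic carbon. Within the data shown here, the one step seen, a group of 2 heavy atoms (1 carbon, 1 selenium; no ring) in place of a group of 2 heavy atoms (1 carbon, 1 sulfur; no ring), sits on the core rather than on this ring and stayed within the scatter, so it bears only loosely here. No step beyond the scatter is expected: a 1.0-fold lower number from compound 1 to compound 3 (0.00 log units; within the scatter). Compound 3 is estimated at 70000 nM, with a range of 30000 nM to 160000 nM.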

Compound 3, concentration for 50% growth inhibition: > 100000 nM
Compound 3 ended at the assay's limit; the forecaster's own chance of this, stated with the estimate: 10%; at least 1.4-fold (0.15 log units) between middle value and limit.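

Within the data shown here, exchanging methoxy for the selenium-bearing group on the ring gives an at least 1.4-fold higher number from compound 1 to compound 3 (0.15 log units; that floor lies within the scatter), the first change made away from the shared core. The reading for compound 3 is a limit and not a number: the limit of > 100000 nM in this assay, at which 1 of the 3 values shown sits. On these data alone, this change therefore has only a floor, which does not separate compound 3 from compound 1 in this assay, and its true size stays unknown.

Open, as far as these compounds go, is whether an amine, a carboxylic acid or a longer chain at this place on the ring would bring the number down.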